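A few compounds are considered here, and "the series" means these few. Any claim that something is new, unique, unknown or untested is made for them only; others in the source may bear on it.

Measured so far, in a functional assay on HT-1080 cells (Homo sapiens), read by transwell migration, with a stated time of 24 h, tested at 1 uM; on this read-out higher numbers stand for a weaker effect at the one concentration tested and lower numbers for a stronger effect:
- compound 1 `CCC(=O)OCc1ccc2oc(=O)c(C(=O)Oc3cccc(Br)c3)cc2c1` gives 40.2%
- compound 2 `CCCC(=O)OCc1ccc2oc(=O)c(C(=O)Oc3cccc(Br)c3)cc2c1` gives 50.5%
- compound 3 `CCCCCC(=O)OCc1ccc2oc(=O)c(C(=O)Oc3cccc(Br)c3)cc2c1` gives 59.3%

All three share one core and differ only in how long the ester chain on that core is. Going from compound 1 to compound 2, the change is methyl in place of hydrogen on a saturated chain carbon, two bonds along the chain from a carbonyl carbon, and it made the step of a number 10.3 percentage points higher from compound 1 to compound 2 (beyond the scatter). Lengthening the chain further, the change propyl in place of hydrogen on a saturated chain carbon, two bonds along the chain from a carbonyl carbon brought a number 19.1 percentage points higher from compound 1 to compound 3 (beyond the scatter), while the step of a number 8.8 percentage points higher from compound 2 to compound 3 (within the scatter) is the smallest of the three.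

Compound 4 `CCCCCCC(=O)OCc1ccc2oc(=O)c(C(=O)Oc3cccc(Br)c3)cc2c1` has not yet been measured. It differs from compound 3 by methyl in place of hydrogen on a saturated chain carbon, five bonds along the chain from a carbonyl carbon. This is the same kind of change as from compound 1 to compound 2, but not the same: there the new methyl sat two bonds along the chain from a carbonyl carbon, here it sits five bonds along the chain from a carbonyl carbon, further out on an already longer chain. Since the later step a number 8.8 percentage points higher from compound 2 to compound 3 (within the scatter) was smaller than the earlier a number 10.3 percentage points higher from compound 1 to compound 2 (beyond the scatter), the expected step from compound 3 to compound 4 in this assay is modest, a number 4.7 percentage points higher from compound 3 to compound 4 (within the scatter). Compound 4 is therefore estimated at 64%, most likely between 51% and 77%.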

Compound 4, a percentage reported as activity, at one concentration (the size of the read-out at that concentration, not a potency): 55.6%
The estimate for compound 4 lay 8.4 percentage points above the measured number, within the range that was stated.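

Set beside the earlier methyl step on a shorter chain, the new methyl step in this assay, a number 3.7 percentage points lower from compound 3 to compound 4 (within the scatter), does not differ from it beyond what two such steps can scatter: the same change on two cores in this assay, a number 10.3 percentage points higher (beyond the scatter) from compound 1 to compound 2 and a number 3.7 percentage points lower (within the scatter) from compound 3 to compound 4, 14 percentage points apart, within the scatter of two such steps The propyl change reads the same way, and the other new steps are a number 5.1 percentage points higher from compound 2 to compound 4 (within the scatter) and a number 15.4 percentage points higher from compound 1 to compound 4 (beyond the scatter), so only compound 1 stands apart from the longer chains: the same change on two cores in this assay, a number 19.1 percentage points higher (beyond the scatter) from compound 1 to compound 3 and a number 5.1 percentage points higher (within the scatter) from compound 2 to compound 4, 14 percentage points apart, within the scatter of two such steps This shows no sign that these changes act differently on different chain lengths, but with so few pairs, read at one concentration, it does not prove that a change carries over unaltered from one compound to another.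

Going by these compounds, all four compounds differ only in the length of a straight ester chain, so the effect of a branched chain, or of a chain ending in an amine or a carboxylic acid, remains open. On these data alone, whether a chain shorter than that of compound 1 would give a lower number in this assay also remains open.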